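Carboxy replaced in compound 3: working notes toward compound 4

The source may report more compounds than this note shows. Statements on the series, on what has been measured and on what is new or still open speak of the compounds shown alone.

Measured so far in a functional assay on cells (Platelet, Homo sapiens) for inhibition; on this read-out lower numbers stand for stronger inhibition and higher numbers for weaker inhibition:
compound 1, `CCOC(=O)c1ccc(-c2nn(-c3ccoc3)c3ccccc23)cc1`, gives 580 nM
compound 2, `CCCCn1nc(-c2ccc(C(=O)OCC)cc2)c2ccccc21`, gives 670 nM
compound 3, `O=C(O)c1ccc(-c2nn(Cc3ccccc3)c3ccccc23)cc1`, gives > 10000 nM

Compound 3 stands at a limit of this assay, (the limit of > 10000 nM in this assay, at which 1 of the 3 values shown sits), and gives no number. Compounds 1 and 2, the two ethyl esters, both give numbers. Going by the values given here, the one measured step, a 1.2-fold higher number from compound 1 to compound 2 (0.06 log units; within the scatter), changes only the group on the aromatic nitrogen and leaves the ester untouched, so it does not bear on the change considered here.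

Compound 4, `CO/N=C\c1ccc(-c2nn(Cc3ccccc3)c3ccccc23)cc1`, differs from compound 3 by a group of 4 heavy atoms (2 carbon, 1 nitrogen, 1 oxygen; no ring) in place of a group of 3 heavy atoms (1 carbon, 2 oxygen; no ring), on an aromatic carbon. The group that leaves carries the hydrogen-bond donor; the esters of compounds 1 and 2 have no such donor and give numbers. A return to a measurable number is expected for compound 4, an at least 6.6-fold lower number from compound 3 to compound 4 (0.82 log units; beyond the scatter). The estimate for compound 4 is 1500 nM, range 300 nM to 8000 nM.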

Compound 4, half-maximal inhibitory concentration: > 10000 nM
Compound 4 ended at the assay's limit; the forecaster's own chance of this, stated with the estimate: 20%; at least 6.6-fold (0.82 log units) between middle value and limit.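

Compound 3 and compound 4 both sit at a limit of this assay, so no step between them can be read: the limit of > 10000 nM in this assay, at which 2 of the 4 values shown sit.

The compounds shown leave open whether any group in place of carboxy on the core of compound 3 gives a measurable number.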